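Aryl swap on the piperazine of compound 1

The compounds below may be only part of what the source reports. "The series", "measured", "known", "first", "only" and "open" are said of these compounds alone.

Measured so far:
compound 1 `CCCc1nc(-c2ccccc2)c(CNCCN2CCN(c3ccccc3Cl)CC2)o1` — 4370 nM
compound 2 `CCCc1nc(-c2ccccc2)c(CNCCCN2CCN(c3cccc(F)c3)CC2)o1` — 3030 nM
compound 3 `CCCc1nc(-c2ccccc2)c(CNCCCN2CCN(c3cccc(Cl)c3)CC2)o1` — 1750 nM

In an assay on HEK293 cells for inhibition of Voltage-dependent T-type calcium channel subunit alpha-1G (Homo sapiens), read by patch clamp (a higher number here means a weaker inhibitor, a lower number a stronger inhibitor), compound 1 gives the highest of the three numbers. Compound 2 lies closest to it, and the gap between them is within the scatter; compound 3 lies furthest, and that gap is beyond the scatter. Among the compounds with values here, compound 2 and compound 3 each differ from compound 1 in more than one place, so no single step links either of them to compound 1. Within the data shown here, the one step that can be drawn, a 1.7-fold lower number from compound 2 to compound 3 (0.24 log units; within the scatter), is a swap of one halogen for another on an aromatic carbon and stays within the scatter.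

Compound 4 `CCCc1nc(-c2ccccc2)c(CNCCN2CCN(c3ccc(OC)cc3)CC2)o1` arises from compound 1 by the change (4-methoxyphenyl in place of 2-chlorophenyl on an amine nitrogen in a ring). Among the measured compounds shown here, no measured pair shows this exchange, and the only step available concerns a different ring and a different kind of group. The data therefore give no ground to expect a shift beyond the scatter in this assay, in either direction. For compound 4 the estimate is 4000 nM, expected to fall between 1300 nM and 12000 nM. That estimate means an expected step of a 1.1-fold lower number from compound 1 to compound 4 (0.04 log units; within the scatter), with wide uncertainty because nothing measured bears directly on it.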

Compound 4, half-maximal inhibitory concentration: 9200 nM
Compound 4: middle estimate off by 2.3-fold (0.36 log units), on the low side; the range from low to high includes it.
By their numbers in this assay, from the lowest: compounds 3, 2 and 1 (each within the scatter of the next, the first and the last beyond it); then compound 4.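

In this assay, within the data shown here, exchanging 2-chlorophenyl for 4-methoxyphenyl on an amine nitrogen in a ring gives a 2.1-fold higher number from compound 1 to compound 4 (0.32 log units; beyond the scatter) and is the only single change from compound 1 that can be read, showing that the aryl group at this position can move the number, if only modestly. Among these compounds, the one earlier step, a 1.7-fold lower number from compound 2 to compound 3 (0.24 log units; within the scatter), swapped one halogen for another on the aryl ring and stayed within the scatter, so it gave no sign that changes to this group register in this assay at all. Nothing at hand accounts for the shift, so the result stands as an observation without an explanation.

The compounds shown leave open whether the step belongs to the methoxy group itself or to its place on the ring, as the two change together here; a 4-chlorophenyl or a 2-methoxyphenyl group on the same nitrogen would separate them. They also leave open how a plain phenyl group would read at this position, and whether the same exchange would give a similar step on the chain carried by compound 2 and compound 3.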